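Another Aryl Swap on the Amide Carbonyl: Compound 3

The compounds below may be only part of what the source reports. "The series", "measured", "known", "first", "only" and "open" are said of these compounds alone.

Within the data shown here, compound 2 `COc1ccc(C(=O)Nc2cccc(-c3oc4cc(-c5ccc(F)cc5)ccc4c(=O)c3O)c2)c(F)c1` is one of two compounds measured in a functional assay on HeLa cells (Homo sapiens) for antiproliferative activity, read by CCK-8 assay, with a stated time of 72 h (a lower number here means a stronger inhibitor, a higher number a weaker inhibitor), where compound 2 gives 16100 nM. Its companion, compound 1 `O=C(Nc1cccc(-c2oc3cc(-c4ccc(F)cc4)ccc3c(=O)c2O)c1)c1ccc(C(F)(F)F)cc1`, gives 17400 nM; the two numbers sit within the scatter of each other, as a 1.1-fold lower number from compound 1 to compound 2 (0.03 log units; within the scatter) shows. Compound 3 `CCCc1ccc(C(=O)Nc2cccc(-c3oc4cc(-c5ccc(F)cc5)ccc4c(=O)c3O)c2)cc1` carries 4-propylphenyl in place of 2-fluoro-4-methoxyphenyl on a carbonyl carbon. Among the measured compounds shown here, the only measured step that bears on this change is that swap of the aryl group on the same carbonyl carbon, which moved nothing beyond the scatter. A further such swap is therefore expected to give a step of about a 1.0-fold lower number from compound 2 to compound 3 (0.00 log units; within the scatter), with no direction beyond the scatter. Compound 3 is estimated at 16000 nM, within the range 6000 nM to 40000 nM.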

Compound 3, half-maximal inhibitory concentration: 8790 nM
Compound 3: middle estimate off by 1.8-fold (0.26 log units), on the high side; the measured number falls inside the stated range.
By their numbers in this assay, from the lowest: compounds 3, 2 and 1 (each within the scatter of the next).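

In this assay the change to 4-propylphenyl gives a 1.8-fold lower number from compound 2 to compound 3 (0.26 log units; within the scatter) and the swap of trifluoromethyl for propyl on an aromatic carbon gives a 2.0-fold lower number from compound 1 to compound 3 (0.30 log units; within the scatter) so a purely carbon substituent, with no hydrogen-bond acceptor in the entering group, still stays within the scatter. Three different aryl groups on this carbonyl carbon now read alike. No evidence is available on what lies behind this result.

On these data alone, whether an amine, a carboxylic acid or a longer chain on the phenyl ring would move the number beyond the scatter remains open.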